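A few compounds are considered here, and "the series" means these few. Any claim that something is new, unique, unknown or untested is made for them only; others in the source may bear on it.

Of the compounds shown here, three built on one shared core have been tested in an ADME assay on PC-3 cells (Homo sapiens) for cytotoxicity, read by WST assay, tested at 100 uM; on this read-out lower numbers stand for less inhibition and higher numbers for more inhibition at the one concentration tested (going by the name of the read-out). Compound 1 `O=C(Nc1ccc(Cl)cn1)C1CCCN(C(=O)c2cc(C(F)(F)F)cc(C(F)(F)F)c2)C1` gives 0%. Compound 2 `COC(=O)c1cccc(NC(=O)C2CCCN(C(=O)c3cc(C(F)(F)F)cc(C(F)(F)F)c3)C2)c1` gives 0% in this assay. Compound 3 `O=C(Nc1cccc([N+](=O)[O-])c1)C1CCCN(C(=O)c2cc(C(F)(F)F)cc(C(F)(F)F)c2)C1` gives 9% in this assay; this is the highest of the three numbers, yet the gap to either neighbour stays inside the scatter of the method, as a number 9 percentage points higher from compound 1 to compound 3 (within the scatter) and a number 9 percentage points higher from compound 2 to compound 3 (within the scatter) show. On this read-out the three compounds cannot be told apart.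

Compound 4 `O=C(Nc1cccc(-c2cnco2)c1)C1CCCN(C(=O)c2cc(C(F)(F)F)cc(C(F)(F)F)c2)C1` has not yet been measured. It differs from compound 3 in one place: 1,3-oxazol-5-yl in place of nitro on an aromatic carbon. The new group sits on an aromatic carbon of a six-membered aromatic ring of carbon only, meta to a large group, where the nitro group stood before.

Two measured steps exchange a group on this same side of the core. no change at the digits printed from compound 1 to compound 2 (within the scatter) and a number 9 percentage points higher from compound 1 to compound 3 (within the scatter) both lie within the scatter, so swaps of this kind have so far left the read-out flat. Nothing measured points to a different outcome for the oxazole. The expected step in this assay is therefore a number 4 percentage points lower from compound 3 to compound 4 (within the scatter), nothing beyond the scatter. Compound 4 is estimated at 5%, with a range from 0% to 20%.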

Compound 4, a percentage reported as inhibition, at one concentration (the size of the read-out at that concentration, not a potency): 9%
Beside the measured number, compound 4's estimate is 4 percentage points below it, and the stated range covers the measured number.
By their numbers in this assay, from the lowest: compounds 1, 2, 3 and 4 (each within the scatter of the next).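

In this assay, the step to a ring-bearing group at this position reads no change at the digits printed from compound 3 to compound 4 (within the scatter): on an aromatic carbon of the six-membered aromatic ring, meta to a large group, a five-membered aromatic ring with 2 hetero atoms and 5 heavy atoms replaces the 3 heavy atoms of nitro without moving the read-out beyond the scatter. The earlier compounds shown here carried no such ring here, and the comparisons with them agree, with a number 9 percentage points higher from compound 2 to compound 4 (within the scatter) for the exchange of methoxycarbonyl and a number 9 percentage points higher from compound 1 to compound 4 (within the scatter) for the exchange of the whole aromatic group on the amide-type nitrogen, so all four compounds remain impossible to tell apart on this read-out. Nothing available explains why the read-out stays flat across these groups.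

As far as these compounds go, it remains open whether a group of a different kind at this position, such as an amine or a carboxylic acid, would give a step beyond the scatter. These numbers also come from a single concentration, so how the four compounds would behave at other concentrations is not known.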